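A few compounds are considered here, and "the series" means these few. Any claim that something is new, unique, unknown or untested is made for them only; others in the source may bear on it.

Measured in a functional assay on DU-145 cells (Homo sapiens) for cytotoxicity, read by ELISA, with a stated time of 2 days; on this read-out higher numbers stand for weaker inhibition and lower numbers for stronger inhibition:
- compound 1 (`Oc1ccc(-c2cc(-c3ccccc3)cc(-c3ccco3)n2)cc1`): 3200 nM
- compound 2 (`Oc1cccc(-c2cc(-c3ccccc3)nc(-c3ccccc3)c2)c1`): 17900 nM
- compound 3 (`Oc1cccc(-c2cc(-c3ccccc3)nc(-c3cccs3)c2)c1`): 19700 nM

Compound 3 and compound 2 lie level within the scatter at the high end of these numbers, while compound 1 gives a clearly lower number. The next change leads to compound 4 (`Oc1cccc(-c2cc(-c3ccccc3)nc(-c3ccco3)c2)c1`), and the difference is furan-2-yl in place of thiophen-2-yl on an aromatic carbon. Among the compounds with values here, one measured step touches this same place: a 1.1-fold higher number from compound 2 to compound 3 (0.04 log units; within the scatter), with thiophen-2-yl in place of phenyl. Compound 1 also holds furan-2-yl and gives 3200 nM, but it differs from compound 4 in more than this group, so it offers only a weak hint. No step beyond the scatter is therefore expected in this assay, with a slight lean towards a lower number. The expected step is a 1.6-fold lower number from compound 3 to compound 4 (0.22 log units; within the scatter) and no larger. Compound 4 is estimated at 12000 nM, with an expected range from 4500 nM to 25000 nM.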

Compound 4, half-maximal inhibitory concentration: 34900 nM
Estimate against measurement, compound 4: 2.9-fold (0.46 log units) below; the whole stated range lies below it.
By their numbers in this assay, from the lowest: compound 1; then compounds 2, 3 and 4 (each within the scatter of the next).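

In this assay, furan-2-yl next to the ring nitrogen gives a 1.8-fold higher number from compound 3 to compound 4 (0.25 log units; within the scatter), and set against phenyl at the same place it gives a 1.9-fold higher number from compound 2 to compound 4 (0.29 log units; within the scatter). The earlier compounds shown here showed only that thiophen-2-yl and phenyl lie level here; with furan-2-yl, all three groups in compounds 2, 3 and 4 stand level, and exchanging sulfur for oxygen within the five-membered aromatic ring leaves the read-out inside the scatter. No measurement at hand bears on why this position stays so flat across these groups.

Open, on these data alone, is whether a group of a different kind at this place, such as an amine or a carboxylic acid, would move the number beyond the scatter. Also open, as far as these compounds go, is whether the same level behaviour at this place holds on the core of compound 1.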